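Rearranged bicyclic amide on a shared benzimidazole-carboxamide core

The source may hold more compounds than are shown below. What is called first, only, known or untested is meant among the compounds shown, and "the series" means these compounds.

Measured compounds:
compound 1 `CCCn1c(NC(=O)c2cc(C)nn2CC)nc2cc(C(N)=O)ccc21` in an assay for activation of interferon regulatory factor 3 (Homo sapiens), read by a luciferase reporter, with a stated time of 20 h (on this read-out higher numbers stand for an effect only at larger amounts of compound and lower numbers for an effect already at smaller amounts), gives > 100000 nM
compound 2 `CCn1nc(C)cc1C(=O)Nc1nc2cc(C(N)=O)cc(OC)c2n1CCCNC(=O)OCc1ccccc1` in this assay gives > 100000 nM
compound 3 `CCCn1c(NC(=O)c2ccc3ccccc3n2)nc2cc(C(N)=O)cc(OC)c21` in this assay gives > 100000 nM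

Each of these values is a limit of the assay, not a number. Among the measured compounds shown here, compound 3 therefore stands at the limit of > 100000 nM in this assay, at which 3 of the 3 values shown sit, where the other two values shown also sit, so no measured step between compounds can be drawn. Compound 4 `CCCn1c(NC(=O)c2nccc3ccccc23)nc2cc(C(N)=O)cc(OC)c21` differs from compound 3 by isoquinolin-1-yl in place of quinolin-2-yl on a carbonyl carbon. With nothing but limits available, no step beyond the usual scatter is expected from compound 3 to compound 4 in this assay; the expected step is a step that the limit leaves unreadable from compound 3 to compound 4. For compound 4 the estimated value in this assay is 150000 nM, within a range from 30000 nM to 1000000 nM, most likely reported again only as a limit.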

Compound 4, half-maximal effective concentration: > 100000 nM
Compound 4 was reported as a limit (the forecaster's own chance of this, stated with the estimate: 85%); the middle value is on the limit's open side.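

Compound 3 and compound 4 are both reported only as limits, not numbers, so no step can be read between them: the limit of > 100000 nM in this assay, at which 4 of the 4 values shown sit.

The compounds shown leave open how isoquinolin-1-yl and quinolin-2-yl on a carbonyl carbon compare in this assay, and which changes to these compounds would give a measurable value.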